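A Methoxy-for-Dichloro Swap on the Benzyl Arm

A few compounds are considered here, and "the series" means these few. Any claim that something is new, unique, unknown or untested is made for them only; others in the source may bear on it.

In a functional assay on NCI-H226 cells (Homo sapiens) for inhibition, read by sulforhodamine B assay, with a stated time of 48 h (on this read-out lower numbers stand for stronger inhibition of growth and higher numbers for weaker inhibition of growth), compound 1 `Nc1cc(N)c2nc(-c3ccccc3)c(NCc3ccc(Cl)c(Cl)c3)nc2c1` gives 46800 nM, the higher of the two numbers at hand. Compound 2 `CCOC(=O)[C@H](CCC(=O)O)NC(=O)c1ccc(Oc2nc3cc(N)cc(N)c3nc2-c2ccccc2)cc1` gives 25100 nM, a value within the usual scatter of that of compound 1, so the two cannot be ordered. Compound 3 `COc1ccc(CNc2nc3cc(N)cc(N)c3nc2-c2ccccc2)cc1` has not yet been measured; it differs from compound 1 by 4-methoxyphenyl in place of 3,4-dichlorophenyl on a saturated chain carbon bound to a nitrogen on an aromatic ring. Among the measured compounds shown here, no measured pair shows a step of this kind, so the change on this assay is expected to be small, probably within the scatter, if anything toward weaker inhibition of growth. Compound 3 is thus expected at 60000 nM, with a range from 20000 nM to 180000 nM, a step of a 1.3-fold higher number from compound 1 to compound 3 (0.11 log units; within the scatter).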

Compound 3, concentration for total growth inhibition: 70800 nM
Estimate against measurement, compound 3: 1.2-fold (0.07 log units) below, within the range that was stated.
By their numbers in this assay, from the lowest: compounds 2, 1 and 3 (each within the scatter of the next, the first and the last beyond it).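

In this assay, 4-methoxyphenyl in place of 3,4-dichlorophenyl gives a 1.5-fold higher number from compound 1 to compound 3 (0.18 log units; within the scatter) and so leaves the number indistinguishable from that of compound 1. Among the compounds shown here, this is the first step read at this position, and it shows that these two groups cannot be told apart here, even though only 4-methoxyphenyl carries a hydrogen-bond acceptor. No evidence at hand bears on this result. As far as these compounds go, whether an amine or a carboxylic acid in place of the methoxy group, or a longer chain on the nitrogen, would move the number beyond the scatter stays open.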